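The source may report more compounds than this note shows. Statements on the series, on what has been measured and on what is new or still open speak of the compounds shown alone.

In a functional assay on HT-29 cells (Homo sapiens) for antiproliferative activity, read by sulforhodamine B assay, with a stated time of 48 h (on this read-out lower numbers stand for stronger inhibition and higher numbers for weaker inhibition), compound 1 `COc1cccc(OS(=O)(=O)c2ccc(N3CCN(C)C3=O)cc2)c1` gives 2500 nM, placing it between compound 2 `CN1CCN(c2ccc(S(=O)(=O)Oc3cccc([N+](=O)[O-])c3)cc2)C1=O` at 26000 nM and compound 3 `COc1cc(OC)cc(OS(=O)(=O)c2ccc(N3CCN(C)C3=O)cc2)c1` at 190 nM. Compound 4 `COc1ccc(OS(=O)(=O)c2ccc(N3CCN(C)C3=O)cc2)cc1` has 4-methoxyphenyl in place of 3-methoxyphenyl on an oxygen, with the same atoms joined differently (4-methoxyphenyl in place of 3-methoxyphenyl on an oxygen). Among the compounds with values here, two measured steps bear on this change, and both are large. Nitro in place of methoxy gave a 10-fold higher number from compound 1 to compound 2 (1.02 log units; beyond the scatter), and methoxy in place of hydrogen gave a 13-fold lower number from compound 1 to compound 3 (1.12 log units; beyond the scatter). These show that changes on this aromatic ring can shift the number strongly, but neither tests this exact swap, so they give no firm direction. In this assay, only a small expected step, within the scatter, is estimated: a 1.2-fold higher number from compound 1 to compound 4 (0.08 log units; within the scatter). The estimated value for compound 4 is 3000 nM, with an expected range from 600 nM to 15000 nM.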

Compound 4, half-maximal inhibitory concentration: > 100000 nM
Compound 4 ended at the assay's limit; the forecaster's own chance of this, stated with the estimate: 3%; at least 33-fold (1.52 log units) between middle value and limit.
By their numbers in this assay, from the lowest: compound 3; then compound 1; then compound 2. At a limit, above all of these: compound 4.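

Changing 3-methoxyphenyl to 4-methoxyphenyl moves one group without adding or removing any atoms, yet it gives an at least 40-fold higher number from compound 1 to compound 4 (1.60 log units; beyond the scatter). The earlier steps shown here changed which groups sat on this ring, whereas this one shows that the place of the methoxy group alone can matter greatly. In this assay compound 4 gives > 100000 nM, which is a limit of the assay and not a number.

On these data alone, it remains open whether this sharp change belongs to methoxy alone. Another group in the same place, such as an amine or a carboxylic acid, could behave differently.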